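A few compounds are considered here, and "the series" means these few. Any claim that something is new, unique, unknown or untested is made for them only; others in the source may bear on it.

Measured so far:
- compound 1 `Cc1cc(C)cc(NC(=O)CN2CCC(c3cccc[n+]3[O-])CC2)c1`: 76%
- compound 2 `O=C(CN1CCC(c2cccc[n+]2[O-])CC1)NC1CCCCC1`: 58%
- compound 3 `O=C(CN1CCC(c2cccc[n+]2[O-])CC1)Nc1cc(Cl)cc(Cl)c1`: 68%

In a functional assay on HEK293 cells for agonist activity at D(4) dopamine receptor (Homo sapiens), read by FLIPR (on this read-out lower numbers stand for smaller maximal responses and higher numbers for larger maximal responses), compound 3 gives 68%, a number that sits within the usual scatter of both other measured compounds: there is a number 8 percentage points lower from compound 1 to compound 3 (within the scatter) and a number 10 percentage points higher from compound 2 to compound 3 (within the scatter). Among the compounds with values here, the one step that goes beyond the scatter is a number 18 percentage points lower from compound 1 to compound 2 (beyond the scatter), where a saturated ring replaced an aromatic ring on the amide-type nitrogen.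

Compound 4 `Cc1cc(Br)ccc1NC(=O)CN1CCC(c2cccc[n+]2[O-])CC1` has not yet been measured. It differs from compound 3 in one place: 4-bromo-2-methylphenyl in place of 3,5-dichlorophenyl on an amide-type nitrogen. Here one substituted aromatic ring swaps for another on the same amide-type nitrogen. The two measured steps of that kind, from compound 1 to compound 3 and from compound 2 to compound 3, stayed within the scatter, so the expected step in this assay is also one within the scatter, with no clear direction: the estimate for compound 4 means no change at the digits printed from compound 3 to compound 4 (within the scatter). Compound 4 is therefore expected to give about 68%, with a likely range from 55% to 80%.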

Compound 4, largest response reached (reported as efficacy), in percent of the reference or control that the assay uses: 61%
Compound 4: the middle estimate sits 7 percentage points above what was measured; the measured number falls inside the stated range.
By their numbers in this assay, from the lowest: compounds 2, 4, 3 and 1 (each within the scatter of the next, the first and the last beyond it).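

In this assay there is a number 7 percentage points lower from compound 3 to compound 4 (within the scatter) when 4-bromo-2-methylphenyl takes the place of 3,5-dichlorophenyl on the amide-type nitrogen, so these two differently substituted aromatic rings cannot be told apart here. Compound 4 also cannot be told apart from the cyclohexyl compound, with a number 3 percentage points higher from compound 2 to compound 4 (within the scatter) in this comparison, so an aromatic ring at this place does not by itself give a clearly larger response. Yet there is a number 15 percentage points lower from compound 1 to compound 4 (beyond the scatter) for this change, so the choice of aromatic ring can matter, although compound 3 stays within the scatter of compound 1.

No measurement shown explains these differences. From the compounds shown here alone, how a benzyl group or a phenyl ring carrying a carboxylic acid or an amine would behave on the amide-type nitrogen remains open.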